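The compounds below may be only part of what the source reports. "The series", "measured", "known", "first", "only" and "open" are said of these compounds alone.

Compound 1, `Cn1c(/C=C2/C(=O)Nc3ccc([N+](=O)[O-])cc32)nc2ccccc21`, carries a nitro group on its shared core, and in a functional assay on MCF7 cells (Homo sapiens) for cytotoxicity, read by MTT assay, with a stated time of 48 h (on this read-out lower numbers stand for stronger inhibition and higher numbers for weaker inhibition), compound 1 has no value to report: the entry for compound 1 stands as "not determined" (no result reported). Compound 2, `Cn1c(/C=C2/C(=O)Nc3ccc(Cl)cc32)nc2ccccc21`, is the analogue in which chlorine takes the place of the nitro group. In this assay compound 2 reaches only a limit and not a number, > 50000 nM. Within the data shown here, compound 1 therefore stands on no number of its own, and the one value shown for the pair is the limit of > 50000 nM in this assay, at which 1 of the 2 values shown sits. Compound 3, `CCn1c(/C=C2/C(=O)Nc3ccc([N+](=O)[O-])cc32)nc2ccccc21`, differs from compound 1 by methyl in place of hydrogen on a saturated chain carbon bound to an aromatic nitrogen. Among the measured compounds shown here, because the only measured value sits at the limit of > 50000 nM in this assay, at which 1 of the 2 values shown sits, there is no measured step from which the size of the change from compound 1 to compound 3 could be read, and no direction beyond the scatter can be claimed for it. With compound 2 giving only a limit, the expectation for compound 3 in this assay is weak inhibition, and compound 3 is estimated at 40000 nM, within a range from 5000 nM to 100000 nM, with a fair chance that only a limit is reported.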

Compound 3, half-maximal inhibitory concentration: > 50000 nM
Compound 3 was reported as a limit (the forecaster's own chance of this, stated with the estimate: 60%); at least 1.2-fold (0.09 log units) between middle value and limit.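

In this assay compound 3 gives > 50000 nM, a limit and not a number. Among these compounds, compound 1 has no result to set against it, so no step from compound 1 to compound 3 can be read. The compounds shown leave open whether any change on the shared core gives a measurable number, as the values so far rest at one reading: the limit of > 50000 nM in this assay, at which 2 of the 3 values shown sit.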